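A few compounds are considered here, and "the series" means these few. Any claim that something is new, unique, unknown or untested is made for them only; others in the source may bear on it.

In a functional assay on HL-60 cells (Homo sapiens) for inhibition, read by MTT assay, with a stated time of 72 h (on this read-out higher numbers stand for weaker inhibition and lower numbers for stronger inhibition), three compounds that share one core have been measured. Compound 2 `CCCCC(=O)N1CCN(c2nnc3nncn3n2)CC1` gives 3130 nM, the lowest number of the three. Compound 3 `CCCCNc1nnc2nncn2n1` gives 36200 nM, and compound 1 `CC(Nc1nnc2nncn2n1)C(=O)O` gives 74300 nM. Among the compounds with values here, the only single-point step among them is a 2.1-fold lower number from compound 1 to compound 3 (0.31 log units; beyond the scatter), a modest move that swaps the group attached to a nitrogen on the aromatic ring; it says nothing about the amide chain of compound 2. The unmeasured compound 4 `CCCC(=O)N1CCN(c2nnc3nncn3n2)CC1` differs from compound 2 by hydrogen in place of methyl on a saturated chain carbon, three bonds along the chain from a carbonyl carbon. Within the data shown here, no measured pair tests shortening a chain by one carbon, so the expectation rests on the general observation that such a trim is a small change in the same part of the molecule, with both neighbours of the change untouched. The expected step is therefore a 1.4-fold higher number from compound 2 to compound 4 (0.16 log units; within the scatter), a shift within the scatter, leaning slightly toward a higher number. Compound 4 is accordingly estimated at 4500 nM in this assay, with a range from 1800 nM to 11000 nM, and the measurement will show where it actually stands.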

Compound 4, half-maximal inhibitory concentration: 9840 nM
Beside the measured number, compound 4's estimate is 2.2-fold (0.34 log units) below it; measured number inside the range.
By their numbers in this assay, from the lowest: compound 2; then compound 4; then compound 3; then compound 1.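

In this assay, the chain on the carbonyl carbon of the amide turns out to be sensitive to a small trim: hydrogen in place of methyl on a saturated chain carbon, three bonds along the chain from a carbonyl carbon, gives a 3.1-fold higher number from compound 2 to compound 4 (0.50 log units; beyond the scatter), a modest step but one beyond the scatter. Within the data shown here, the earlier compounds offered only one single-place comparison, and that one concerned a group on a nitrogen on an aromatic ring, so this is the first measured sign that losing a single carbon from this amide chain, butyl to propyl when read one bond further out, can shift the number. Nothing at hand explains why this one carbon has an effect of this size.

On these data alone, two compounds give a single step, not a trend, so it remains open whether a longer chain such as pentyl would lower the number further or raise it again. As far as these compounds go, how a branched chain, or an amine or a carboxylic acid carried on this chain, would compare with butyl also remains unknown.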